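This account rests on a few compounds, and the source may have more. Where it says the series, first, only, none or still open, it means among the compounds named here.

Compound 1 `Cc1ccc(-n2nc(-c3ccc(C(F)(F)F)cc3O)nc2-c2ccccc2O)cc1`: 81800 nM
Compound 2 `Oc1cc(C(F)(F)F)ccc1-c1nc(-c2ccccc2O)n(-c2ccc(Br)cc2)n1`: 29600 nM

Within the data shown here, in a toxicity assay on HaCaT cells (Homo sapiens) for cytotoxicity, read by MTT assay (on this read-out higher numbers stand for weaker inhibition and lower numbers for stronger inhibition), compound 2 gives 29600 nM, the lower of the two numbers so far. The next compound to be tested is compound 3 `Oc1cc(C(F)(F)F)ccc1-c1nc(-c2ccccc2O)n(-c2cccc(C(F)(F)F)c2)n1`, which keeps the shared core and changes one group: 3-(trifluoromethyl)phenyl in place of 4-bromophenyl on an aromatic nitrogen.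

Among the measured compounds shown here, only one measured step bears on this change. It is a 2.8-fold lower number from compound 1 to compound 2 (0.44 log units; beyond the scatter), a modest move beyond the scatter, and it came from bromo in place of methyl on an aromatic carbon. That step altered the same aromatic ring, so it gives a rough idea of how far a swap there can move the number. For the measured compounds named here, it says nothing about the direction for the new group, since no measured compound carries 3-(trifluoromethyl)phenyl. A step no larger than that modest one is therefore expected, with its direction open. The expected step is a 1.2-fold higher number from compound 2 to compound 3 (0.07 log units; within the scatter), which would lie within the scatter. For compound 3 the estimated value is 35000 nM, with an expected range from 14000 nM to 90000 nM.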

Compound 3, half-maximal inhibitory concentration: 54300 nM
Estimate against measurement, compound 3: 1.6-fold (0.19 log units) below, within the range that was stated.
By their numbers in this assay, from the lowest: compounds 2, 3 and 1 (each within the scatter of the next, the first and the last beyond it).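

In this assay, the new group on the aromatic nitrogen gives a 1.8-fold higher number from compound 2 to compound 3 (0.26 log units; within the scatter), and the comparison with 4-methylphenyl gives a 1.5-fold lower number from compound 1 to compound 3 (0.18 log units; within the scatter), so both steps lie within the scatter even though the two neighbouring compounds differ from each other beyond it. This is also the first change shown that enlarges the group at this position, with 10 heavy atoms entering and 7 leaving, and that larger 3-(trifluoromethyl)phenyl group produces no step beyond the scatter from either neighbour. No measurement here explains these numbers.

The swap from 4-bromophenyl to 3-(trifluoromethyl)phenyl changes both the substituent and its place on the ring, so these compounds cannot show which of the two matters, or whether either matters at all. Going by these compounds, it also remains open whether an amine or a carboxylic acid on this ring, or a longer alkyl chain in place of the ring, would move the number beyond the narrow span seen so far.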